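Compound 2 to Compound 4: a Larger Group on Selenium

This account rests on a few compounds, and the source may have more. Where it says the series, first, only, none or still open, it means among the compounds named here.

Three compounds have numbers in a functional assay on HepG2 cells (Homo sapiens) for cytotoxicity, read by MTT assay, with a stated time of 72 h; a higher number here means a weaker inhibitor of growth, a lower number a stronger inhibitor of growth. Compound 1 `CS/C(=N\C(=O)c1csc([N+](=O)[O-])c1)NC(=O)c1csc([N+](=O)[O-])c1` gives 63400 nM. Compound 2 `C[Se]/C(=N\C(=O)c1ccco1)NC(=O)c1ccco1` gives 760 nM, and compound 3 `C[Se]/C(=N\C(=O)c1ccno1)NC(=O)c1ccno1` gives 510 nM. Among these three, compound 2 holds the second highest number; its nearest neighbour is compound 3, whose number lies within the usual scatter of this assay, while compound 1 sits far beyond the scatter at the high end.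

Compound 4 `O=C(/N=C(/NC(=O)c1ccco1)[Se]Cc1ccccc1)c1ccco1` has not yet been measured in this assay. It differs from compound 2 in a single place: phenyl in place of hydrogen on a saturated chain carbon bound to a selenium atom. Among the compounds with values here, no pair of measured compounds shows a change of this kind, so there is no measured step to lean on. The change leaves the rest of compound 2 untouched, and the account therefore expects only a modest step in this assay, one that could fall in either direction and need not exceed the scatter. The estimate means a step of a 1.2-fold lower number from compound 2 to compound 4 (0.07 log units; within the scatter) that is expected to stay small. Compound 4 is expected to give about 650 nM, with a range from 200 nM to 2200 nM.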

Compound 4, concentration for 50% growth inhibition: 7650 nM
For compound 4 the middle estimate is 12-fold (1.07 log units) below the measured one; the whole stated range lies below it.
By their numbers in this assay, from the lowest: compounds 3 and 2 (each within the scatter of the next); then compound 4; then compound 1.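

The group on selenium is not a silent place on this molecule: going from methyl to benzyl brings a 10-fold higher number from compound 2 to compound 4 (1.00 log units; beyond the scatter) in this assay with the rest of compound 2 unchanged. The earlier compounds shown here could not show this, as no measured pair among them differed at this place alone. Nothing given here accounts for the size of this step.

With only methyl and benzyl compared on selenium, the compounds shown leave open whether the weakening comes with any larger group there or with the phenyl ring in particular. An ethyl group or a longer chain of saturated carbon on selenium would separate those two readings, and a benzyl group bearing an amine on its phenyl ring would show whether that ring tolerates further change.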